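Moving a Fluorine on the Pendant Phenyl Ring

The source may report more compounds than this note shows. Statements on the series, on what has been measured and on what is new or still open speak of the compounds shown alone.

Compound 2, `CN(C)CCn1c(=O)c(=Cc2ccc(F)c(F)c2)s/c1=C1\C(=O)Nc2cc(F)ccc21`, gives 6400 nM in a functional assay on NCI-H460 cells (Homo sapiens) for inhibition, read by MTT assay, with a stated time of 72 h; a lower number here means a stronger inhibitor, a higher number a weaker inhibitor.
Compound 3, `CCN(CC)CCCn1c(=O)c(=Cc2ccc(F)c(F)c2)s/c1=C1\C(=O)Nc2cc(F)ccc21`, gives 1120 nM in this assay.
Compound 1, `COc1cc(C=c2s/c(=C3\C(=O)Nc4ccc(F)cc43)n(CCN(C)C)c2=O)cc(OC)c1OC`, gives 1700 nM in this assay.

Compound 2 carries the highest number of the three measured compounds; compound 1 and compound 3 both sit at lower numbers, each beyond the scatter. Compound 4, `CN(C)CCn1c(=O)c(=Cc2ccc(F)cc2F)s/c1=C1\C(=O)Nc2cc(F)ccc21`, differs from compound 2 by 2,4-difluorophenyl in place of 3,4-difluorophenyl on a double-bonded chain carbon bound to an aromatic carbon. Going by the values given here, the one measured step, a 5.7-fold lower number from compound 2 to compound 3 (0.76 log units; beyond the scatter), concerns the amine on the chain rather than the pendant phenyl ring, so no measured step bears on the change at hand. Among the compounds with values here, compound 1 and compound 2 differ in more than one place, and their values show only that compound 1 gives the lower number. With nothing to guide the direction, the expected step is one within the scatter, a 1.3-fold lower number from compound 2 to compound 4 (0.11 log units; within the scatter). Compound 4 is therefore estimated at 5000 nM, with a range from 1800 nM to 14000 nM.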

Compound 4, half-maximal inhibitory concentration: 3200 nM
Estimate against measurement, compound 4: 1.6-fold (0.19 log units) above; the range from low to high includes it.
By their numbers in this assay, from the lowest: compounds 3, 1, 4 and 2 (each within the scatter of the next, the first and the last beyond it).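

Going by these compounds alone, this is the first measured change on the pendant phenyl ring itself. With the atoms unchanged and only one fluorine moved, 2,4-difluorophenyl in place of 3,4-difluorophenyl on a double-bonded chain carbon bound to an aromatic carbon gives a 2.0-fold lower number from compound 2 to compound 4 (0.30 log units; within the scatter) in this assay, so the two fluorine patterns cannot be told apart here. No measurement shown speaks to what lies behind this small step. Still open, on these data alone, is how a dichlorophenyl or a pyridine ring would fare at this place, and whether 2,4-difluorophenyl would give a similar result when paired with the amine chain of compound 3.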